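A few compounds are considered here, and "the series" means these few. Any claim that something is new, unique, unknown or untested is made for them only; others in the source may bear on it.

Measured set:
- compound 1 `O=C1NC(=S)/C(=C/c2ccc(Cl)cc2)S1`, 3.91%
- compound 2 `O=C1NC(=S)/C(=C/c2ccccc2Cl)S1`, -11.5%
- compound 3 `O=C1NC(=S)/C(=C/c2ccccc2F)S1`, 1.66%

In a functional assay on HEp-2 cells (Homo sapiens) for cytotoxicity, read by MTT assay, with a stated time of 72 h, tested at 2.5 ug/mL (on this read-out lower numbers stand for less inhibition of growth and higher numbers for more inhibition of growth at the one concentration tested), compound 2 gives -11.5%, the lowest of the three numbers; compound 3 and compound 1 stand higher, each beyond the scatter. Among the compounds with values here, the only single-point step recorded is a number 13.2 percentage points higher from compound 2 to compound 3 (beyond the scatter), a modest shift. Compound 4 `O=C1NC(=S)/C(=C/c2ccc(Cl)cc2Cl)S1` carries a second chloro: chloro in place of hydrogen on an aromatic carbon. Within the data shown here, no measured step covers adding a chloro to the shared core, so the fluoro-for-chloro step is only a loose guide to how much one aromatic substituent moves this read-out, and all three measured numbers sit near zero. A step of about a number 9.5 percentage points higher from compound 2 to compound 4 (within the scatter) is therefore expected, no larger than the scatter. Compound 4 is estimated at -2%, within -16% to 14%.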

Compound 4, percent growth inhibition at one concentration: 15.3%
For compound 4 the middle estimate is 17.3 percentage points below the measured one; the measured number lies above the stated range.
By their numbers in this assay, from the lowest: compound 2; then compounds 3 and 1 (each within the scatter of the next); then compound 4.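

In this assay, chloro in place of hydrogen on an aromatic carbon gives a rise from either side of the pair: a number 26.8 percentage points higher from compound 2 to compound 4 (beyond the scatter), and a number 11.4 percentage points higher from compound 1 to compound 4 (beyond the scatter). Within the data shown here, these are the first steps that add a group to the shared core, and both run in the same direction, so the second chloro raises the number whichever single chloro is already present. Nothing at hand explains this rise.

On these data alone, whether a methoxy group or an amine on this aromatic carbon would move the number the same way stays open. Also open, as far as these compounds go, is whether the rise holds at other concentrations, since only one was tested.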